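The compounds below may be only part of what the source reports. "The series", "measured", "known", "first", "only" and "open" are said of these compounds alone.

Measured so far in a functional assay on NCI-H226 cells (Homo sapiens) for cytotoxicity, read by sulforhodamine B assay, with a stated time of 48 h, tested at 0.1 uM; on this read-out lower numbers stand for a stronger effect and higher numbers for a weaker effect at the one concentration tested:
- compound 1 `COc1cc(-c2cc(/C=C/C(=O)c3ccc(Cl)c(Cl)c3)[nH]n2)cc(OC)c1OC`: compound 1 gives 103%
- compound 2 `COc1ccc(C(=O)/C=C/c2cc(-c3cc(OC)c(OC)c(OC)c3)n[nH]2)cc1OC`: compound 2 gives 97%

Going by the values given here, compound 2 holds the lower of the two numbers in this assay, but the only comparison available, the change a number 6 percentage points lower from compound 1 to compound 2 (within the scatter) on exchanging 3,4-dichlorophenyl for 3,4-dimethoxyphenyl on the carbonyl carbon, is within the scatter, so compound 1 and compound 2 are not separated by these data. Both sit at the level of no measurable effect at the single concentration tested.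

Compound 3 `COc1cc(-c2cc(/C=C/C(=O)c3ccc(F)c(F)c3)[nH]n2)cc(OC)c1OC` differs from compound 2 by 3,4-difluorophenyl in place of 3,4-dimethoxyphenyl on a carbonyl carbon. Among the compounds with values here, the one measured step that bears on this place is a number 6 percentage points lower from compound 1 to compound 2 (within the scatter), and it was within the scatter; compound 1, which carries a 3,4-dichlorophenyl at the same place, also sits at the no-effect level. Nothing in the series therefore points to a step beyond the scatter, and the expected change a number 3 percentage points higher from compound 2 to compound 3 (within the scatter) is flat. Compound 3 is expected to give about 100% in this assay, with a range from 88% to 112%.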

Compound 3, a percentage reported as activity, at one concentration (the size of the read-out at that concentration, not a potency): 97%
Compound 3: middle estimate off by 3 percentage points, on the high side; the measured number falls inside the stated range.
By their numbers in this assay, from the lowest: compounds 2, 3 and 1 (each within the scatter of the next).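

In this assay the exchange on the carbonyl carbon gives no change at the digits printed from compound 2 to compound 3 (within the scatter) when 3,4-difluorophenyl enters for 3,4-dimethoxyphenyl, and a number 6 percentage points lower from compound 1 to compound 3 (within the scatter) when it enters for 3,4-dichlorophenyl. Going by these compounds alone, this place now carries three substituted phenyl groups, and no step among them lies beyond the scatter. The new step also shows that going from 10 heavy atoms with 2 hydrogen-bond acceptors to 8 heavy atoms with 0 hydrogen-bond acceptors leaves the read-out at the no-effect level, and no supporting data bear on why this position appears so insensitive.

Open, from the compounds shown here alone, is whether any group at this place can move the read-out away from the no-effect level, for instance a phenyl carrying a dimethylamino group or a carboxylic acid, or a longer alkyl chain in place of the phenyl ring. Also open, going by these compounds, is whether compound 1, compound 2 and compound 3 would separate at a higher concentration, since a read-out at one concentration, with all three at the no-effect level, gives no ranking among them.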